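A few compounds are considered here, and "the series" means these few. Any claim that something is new, unique, unknown or untested is made for them only; others in the source may bear on it.

In an ADME assay on L6 cells (Rattus norvegicus) for cytotoxicity, read by microscopy and resazurin assay, with a stated time of 72 h (on this read-out higher numbers stand for an effect only at larger amounts of compound and lower numbers for an effect already at smaller amounts), three compounds of this set have been examined. Compound 1 `Cc1cc(/C=C2\S/C(=N\c3ccccc3)N(C3CCCCC3)C2=O)c(C)n1-c1ccc(C(F)(F)F)cc1` reached only a limit of the measurement and not a number: in this assay compound 1 gives > 170000 nM. That limit is described by the limit of > 170000 nM in this assay, at which 1 of the 3 values shown sits. Compound 2 `C/N=C1\S/C(=C\c2cnn(-c3ccccc3C(F)(F)F)c2)C(=O)N1C` gives 34000 nM in this assay. Compound 3 `Cc1cc(/C=C2\SC(=O)NC2=O)c(C)n1-c1ccccc1C(F)(F)F` gives 64000 nM in this assay, which is the higher of the two numbers recorded; its nearest neighbour is compound 2, and the two values sit within the usual scatter of each other, so no order between them can be claimed. The remaining compound in this series, compound 4 `Cc1cc(/C=C2/SC(=S)NC2=O)c(C)n1-c1ccccc1C(F)(F)F`, has not yet been measured. Compound 4 differs from compound 3 in one place: a group of 8 heavy atoms (4 carbon, 1 nitrogen, 1 oxygen, 2 sulfur; one five-membered non-aromatic ring with 2 hetero atoms) in place of a group of 8 heavy atoms (4 carbon, 1 nitrogen, 2 oxygen, 1 sulfur; one five-membered non-aromatic ring with 2 hetero atoms), on an aromatic carbon. Going by the values given here, no pair of measured compounds traces this exchange, so any expectation rests on compound 3 alone. The expected step from compound 3 to compound 4 in this assay is a 1.3-fold lower number from compound 3 to compound 4 (0.11 log units; within the scatter), a step that is not expected to go beyond the scatter in either direction, with perhaps a slight lean to a lower number. Compound 4 is therefore estimated to give about 50000 nM in this assay, within a range from 20000 nM to 130000 nM.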

Compound 4, half-maximal effective concentration: 9000 nM
Estimate against measurement, compound 4: 5.6-fold (0.74 log units) above, and the stated range ends above it.
By their numbers in this assay, from the lowest: compound 4; then compounds 2 and 3 (each within the scatter of the next). At a limit, above all of these: compound 1.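

In this assay, going by these compounds alone, the exchange on this aromatic carbon of the five-membered aromatic ring with 1 nitrogen gives a 7.1-fold lower number from compound 3 to compound 4 (0.85 log units; beyond the scatter), the first step in this set that traces a single change and the first evidence that this place can move the number beyond the scatter. The group that leaves and the group that enters have the same count of 8 heavy atoms, the same five-membered non-aromatic ring with 2 hetero atoms, the same 3 double bonds outside aromatic rings and the same counts of hydrogen-bond donors and acceptors, so the exchange of one oxygen for one sulfur is the only difference in these counts. Nothing measured among these compounds accounts for the size of this step.

On these data alone, this one pair alone traces the exchange, and whether it gives a similar step on another core stays open. Also open, as far as these compounds go, is how this assay would read if a group carrying an amine or a carboxylic acid stood at this place instead of either ring.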